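From a benzyloxy arm to a bare phenyl ring

The source may report more compounds than this note shows. Statements on the series, on what has been measured and on what is new or still open speak of the compounds shown alone.

Three measured compounds share one core: an amide joining a benzoic acid to a second aromatic ring that carries an ether-linked group. Compound 1 `CCCCCOc1cccc(C(=O)Nc2cccc(C(=O)O)c2)c1` gives 2540 nM in an assay on isolated protein for agonist activity at Bile acid receptor (Homo sapiens), read by TR-FRET, with a stated time of 3 h, in the absence of a further agent; a higher number here means that more compound is needed for the effect, a lower number that less compound is needed. Compound 2 `Cc1cccc(COc2cccc(C(=O)Nc3cccc(C(=O)O)c3)c2)c1` gives 1860 nM in this assay, and compound 3 `Cc1ccc(COc2cccc(C(=O)Nc3cccc(C(=O)O)c3)c2)cc1` gives 1430 nM in this assay. The steps into compound 3 are a 1.8-fold lower number from compound 1 to compound 3 (0.25 log units; within the scatter) and a 1.3-fold lower number from compound 2 to compound 3 (0.11 log units; within the scatter), so compound 3 sits at the low end of these three numbers without standing apart from the others.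

Compound 4 `O=C(O)c1cccc(NC(=O)c2cccc(-c3ccccc3)c2)c1` departs from this series in a different way: phenyl in place of (4-methylbenzyl)oxy on an aromatic carbon. Among the compounds with values here, every measured step so far swapped only the group on the carbon bound to the ring oxygen, as in a 1.4-fold lower number from compound 1 to compound 2 (0.14 log units; within the scatter) and a 1.3-fold lower number from compound 2 to compound 3 (0.11 log units; within the scatter), while the oxygen and its attached carbon stayed in place. None of them removed that linker as compound 4 does, so the measured steps give little guidance here, and the expectation is wide: no confident step beyond the scatter in either direction.

For compound 4 the estimate in this assay is 3000 nM, with a range from 800 nM to 12000 nM, which means an expected step of a 2.1-fold higher number from compound 3 to compound 4 (0.32 log units; beyond the scatter).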

Compound 4, half-maximal effective concentration: 25 nM
Compound 4: the middle estimate sits 120-fold (2.08 log units) above what was measured; the whole stated range lies above it.
By their numbers in this assay, from the lowest: compound 4; then compounds 3, 2 and 1 (each within the scatter of the next).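

In this assay, the group at this position matters far more than the earlier swaps suggested: phenyl in place of the ether-linked arm gives a 57-fold lower number from compound 3 to compound 4 (1.76 log units; beyond the scatter), and the other two arms give a 74-fold lower number from compound 2 to compound 4 (1.87 log units; beyond the scatter) and a 100-fold lower number from compound 1 to compound 4 (2.01 log units; beyond the scatter). Changing the far end of the arm left the numbers within the scatter of one another, whereas a ring sitting directly on the aromatic carbon, with the oxygen and its attached carbon gone, moves the number well beyond the scatter whichever arm leaves. Nothing in the available data explains why the number falls so far.

The compounds shown do not separate the loss of the oxygen from the loss of the attached carbon. They also leave open whether the low number survives an added group on the new phenyl ring, such as a methyl or an amine.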